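Removing one trifluoromethyl from a diaryl urea

The source may report more compounds than this note shows. Statements on the series, on what has been measured and on what is new or still open speak of the compounds shown alone.

Measured so far:
Compound 1, `O=C(Nc1cccc(-n2cc(-c3ccncc3)c(-c3cc(O)cc(Cl)c3)n2)c1)Nc1ccc(Cl)c(Cl)c1`, gives 57%.
Compound 2, `COc1cc(Cl)cc(-c2nn(-c3cccc(NC(=O)Nc4cc(C(F)(F)F)cc(C(F)(F)F)c4)c3)cc2-c2ccncc2)c1`, gives -12%.

Of the compounds shown here, two have been tested in a functional assay on RPMI-8226 cells (Homo sapiens) for inhibition, read by sulforhodamine B assay, with a stated time of 48 h, tested at 1 uM; on this read-out lower numbers stand for a stronger effect and higher numbers for a weaker effect at the one concentration tested. Compound 1 is a urea carrying a dichlorophenyl group and a hydroxyl on the chlorophenyl ring; in this assay compound 1 gives 57%. Compound 2 carries a bis(trifluoromethyl)phenyl urea and a methoxy in place of the hydroxyl; in this assay compound 2 gives -12%, the lower of the two numbers and beyond the scatter of compound 1.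

Compound 3, `COc1cc(Cl)cc(-c2nn(-c3cccc(NC(=O)Nc4cccc(C(F)(F)F)c4)c3)cc2-c2ccncc2)c1`, has not been measured. It differs from compound 2 in one place: hydrogen in place of trifluoromethyl on an aromatic carbon. Among the measured compounds shown here, no pair differing in only one place has been measured, so the size of this step cannot be read from the data. Since compound 2 already sits at the strong end of the read-out with -12%, a move toward weaker inhibition is expected, of modest size but likely beyond the scatter, giving a step of a number 27 percentage points higher from compound 2 to compound 3 (beyond the scatter). Compound 3 is therefore estimated to give 15%, within -15% to 50%.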

Compound 3, a percentage reported as activity, at one concentration (the size of the read-out at that concentration, not a potency): 22%
Compound 3: the middle estimate sits 7 percentage points below what was measured, and the stated range covers the measured number.
By their numbers in this assay, from the lowest: compound 2; then compound 3; then compound 1.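

In this assay, among the compounds shown here, the step from the bis(trifluoromethyl)phenyl urea to the version with a single trifluoromethyl group is a number 34 percentage points higher from compound 2 to compound 3 (beyond the scatter), the first change in a single place that can be read. It shows that this position on the six-membered aromatic ring, meta to a large group and meta to the remaining trifluoromethyl group, is sensitive to the change: replacing trifluoromethyl with hydrogen weakens the effect at the one concentration tested, by more than the usual scatter. No measurement shown here explains why this change has that effect.

The compounds shown leave open how the same position would respond to a different group in place of the hydrogen, such as a nitrile, an amine or a methyl, and whether the remaining trifluoromethyl group matters in the same way. Compound 1 differs from compound 2 and compound 3 in more than one place, so the separate steps for its dichlorophenyl urea and its hydroxyl cannot be read.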